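The source may hold more compounds than are shown below. What is called first, only, known or untested is meant among the compounds shown, and "the series" means these compounds.

Measured compounds:
Compound 1 `CC(=O)Nc1cccc(-n2c(Nc3ccc(F)cc3)nc3cnc(Nc4ccc(N5CCN(C)CC5)cc4)nc32)c1` in a functional assay on HCC827 cells (Homo sapiens) for antiproliferative activity, read by MTT assay, with a stated time of 72 h (on this read-out higher numbers stand for weaker inhibition and lower numbers for stronger inhibition), gives 10 nM.
Compound 2 `CN1CCN(c2ccc(Nc3ncc4nc(Nc5ccc(F)cc5)n([C@@H]5CCCNC5)c4n3)cc2)CC1` in this assay gives 120 nM.

Within the data shown here, compound 2 stands at the higher of the two numbers seen so far, and its nearest neighbour is compound 1, which is also the only compound that stands next to it in structure. Among the measured compounds shown here, the one measured step is a 12-fold higher number from compound 1 to compound 2 (1.08 log units; beyond the scatter), brought about by piperidin-3-yl in place of 3-acetamidophenyl on an aromatic nitrogen.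

Compound 3 `CN1CCN(c2ccc(Nc3ncc4nc(Nc5ccc(F)cc5)n([C@H]5CCN(C(=O)CO)C5)c4n3)cc2)CC1` has not yet been measured. It differs from compound 2 by 1-((hydroxymethyl)carbonyl)pyrrolidin-3-yl in place of piperidin-3-yl on an aromatic nitrogen. The measured step from compound 1 to compound 2 concerns a different exchange on the same nitrogen, so it offers no direct guide to the present change; what it does show is that this position can move the read-out by a large amount. For the measured compounds named here, with no step that covers the present change, the outcome for compound 3 is expected to lie near compound 2, with a step of modest size and no firm direction, a 1.7-fold lower number from compound 2 to compound 3 (0.23 log units; within the scatter). Compound 3 is therefore estimated at 70 nM, within a range from 20 nM to 250 nM.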

Compound 3, half-maximal inhibitory concentration: 380 nM
Beside the measured number, compound 3's estimate is 5.4-fold (0.73 log units) below it; the measured number lies above the stated range.
By their numbers in this assay, from the lowest: compound 1; then compound 2; then compound 3.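

In this assay, replacing piperidin-3-yl with 1-((hydroxymethyl)carbonyl)pyrrolidin-3-yl on the aromatic nitrogen gives a 3.2-fold higher number from compound 2 to compound 3 (0.50 log units; beyond the scatter), so the read-out at this position also responds to an exchange between two non-aromatic rings, and not only to the loss of 3-acetamidophenyl. Set against the step of a 12-fold higher number from compound 1 to compound 2 (1.08 log units; beyond the scatter), the step of a 38-fold higher number from compound 1 to compound 3 (1.58 log units; beyond the scatter) is the larger, and among the three compounds the 3-acetamidophenyl group keeps the lowest number. Nothing measured here accounts for the rise seen with the new group.

The exchange alters the ring size and adds the (hydroxymethyl)carbonyl group on the ring nitrogen in a single move, so the compounds shown cannot tell how much of the step belongs to either change. A bare pyrrolidin-3-yl group would speak to the ring alone and 1-((hydroxymethyl)carbonyl)piperidin-3-yl to the added group alone, while an acetyl group or a longer acyl chain on that ring nitrogen would show whether the terminal hydroxyl matters.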